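Extending the chain of compound 3 toward compound 4

The compounds below may be only part of what the source reports. "The series", "measured", "known", "first", "only" and "open" are said of these compounds alone.

Of the compounds shown here, three sharing one core have been measured in an assay on isolated protein for inhibition of Dihydrofolate reductase (Mus musculus); on this read-out lower numbers stand for lower potency and higher numbers for higher potency (the scale is a negative logarithm). Compound 3 `CC1(C)N=C(N)N=C(N)N1c1cccc(CCc2ccccc2)c1` gives 8.19, the highest of the three numbers. Compound 2 `CC1(C)N=C(N)N=C(N)N1c1ccc(CCc2cc(Cl)ccc2S(=O)(=O)F)c(Cl)c1` gives 7.85, a value beyond the scatter below compound 3, and compound 1 `CC1(C)N=C(N)N=C(N)N1c1ccc(OCC2CCC(COc3ccc(S(=O)(=O)F)cc3)CC2)c(Cl)c1` gives 6.37, the furthest from compound 3. Compound 4 `CC1(C)N=C(N)N=C(N)N1c1cccc(CCCCOc2ccccc2)c1` has not yet been measured in this assay. It differs from compound 3 as follows: 2-phenoxyethyl in place of phenyl on a saturated chain carbon, two bonds along the chain from an aromatic carbon. Among the compounds with values here, no step between measured compounds isolates this change, so the expectation rests on the two higher values of compounds 2 and 3. Compound 4 is expected to show a step of a number 0.39 log units lower from compound 3 to compound 4 (beyond the scatter) that is small and, if anything, downward. Compound 4 is estimated at 7.8, within 7.2 to 8.4.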

Compound 4, logarithm of the reciprocal of the active concentration, log(1/C): 8.35
Beside the measured number, compound 4's estimate is 0.55 log units below it, and the stated range covers the measured number.
By their numbers in this assay, from the lowest: compound 1; then compound 2; then compounds 3 and 4 (each within the scatter of the next).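

Putting 2-phenoxyethyl in place of phenyl on this saturated chain carbon gives a step of a number 0.16 log units higher from compound 3 to compound 4 (within the scatter) in this assay. This position therefore takes the larger group, with its 9 heavy atoms and one hydrogen-bond acceptor, without a loss beyond the scatter. No measurement shown here accounts for this result. The compounds shown leave open whether the oxygen or the added chain length matters, which an all-carbon chain of the same length would separate. They also leave open whether a longer chain or a terminal amine would hold this level.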